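The source may report more compounds than this note shows. Statements on the series, on what has been measured and on what is new or still open speak of the compounds shown alone.

Compound 1 `CSc1ccc2nc(C)cc(OCC(=O)Nc3cc(C)cc(C)c3)c2c1`: in a toxicity assay on HepG2 cells (Homo sapiens) for inhibition, read by CellTiter-Glo, with a stated time of 48 h (on this read-out higher numbers stand for weaker inhibition and lower numbers for stronger inhibition), compound 1 gives > 100000 nM, which is a limit of the assay rather than a number.
Compound 2 `COc1ccc2nc(C)cc(OCC(=O)NCc3cc(C)cc(C)c3)c2c1`: in this assay compound 2 gives > 100000 nM, again a limit and not a number.
Compound 3 `COc1ccc2nc(C)cc(NCC(=O)Nc3cc(C)cc(C)c3)c2c1`: in this assay compound 3 gives 6310 nM.

Compound 2 therefore stands at the edge of what this assay can report: no inhibition strong enough to be measured was seen up to the top concentration tested. That is the common outcome here, since (the limit of > 100000 nM in this assay, at which 2 of the 3 values shown sit). Among the measured compounds shown here, only compound 3 shows a number, and it is the one compound whose side chain is attached through a nitrogen rather than an oxygen on the shared core.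

The new compound is compound 4 `COc1ccc2nc(C)cc(OCC(=O)Nc3ccncc3)c2c1`. It keeps the core and the linker of compound 2 and changes the group on the amide nitrogen: pyridin-4-yl in place of 3,5-dimethylbenzyl on an amide-type nitrogen.

For the measured compounds named here, no pair of measured compounds differs in just one place, so no measured step tells how large a change of this kind is in this assay. The expectation for compound 4 rests on compound 2 sitting at the limit, and the step of a number no higher from compound 2 to compound 4 (the limit leaves the size open) is expected to be none beyond the scatter. Compound 4 is expected to come out near 100000 nM, in a range from 30000 nM to 300000 nM, most likely again as a limit.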

Compound 4, half-maximal inhibitory concentration: > 100000 nM
Compound 4 was reported as a limit; the forecaster's own chance of this, stated with the estimate: 70%; the middle value sits exactly at the limit.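

In this assay compound 4 gives > 100000 nM, which is a limit and not a number. Compound 2 also sits at a limit, so no step from one to the other can be read, and such limits are common here: the limit of > 100000 nM in this assay, at which 3 of the 4 values shown sit.

The compounds shown leave open whether pyridin-4-yl in place of 3,5-dimethylbenzyl changes inhibition at all, and by how much.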